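Ester side-chain variation on the lactone series

This account rests on a few compounds, and the source may have more. Where it says the series, first, only, none or still open, it means among the compounds named here.

Compound 2 `CC(C)CC(=O)O[C@H]1C[C@@H](C)C=C2C=C[C@H](C)[C@H](CC[C@@H]3C[C@@H](O)CC(=O)O3)C21` carries an isobutyl group on the carbonyl carbon of its ester. Among the measured compounds shown here, in an assay for inhibition of 3-hydroxy-3-methylglutaryl-coenzyme A reductase (Rattus norvegicus) (on this read-out higher numbers stand for weaker inhibition and lower numbers for stronger inhibition), compound 2 gives 5.4 nM, the lowest of the two numbers measured so far. For the measured compounds named here, its only measured neighbour is compound 1 `C[C@H]1C=C2C=C[C@H](C)[C@H](CC[C@@H]3C[C@@H](O)CC(=O)O3)C2[C@@H](OC(=O)C2CC2)C1`, which in this assay gives 38.6 nM; the step of a 7.1-fold lower number from compound 1 to compound 2 (0.85 log units; beyond the scatter) arises from isobutyl in place of cyclopropyl on a carbonyl carbon.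

Compound 3 `C=C(C)CC(=O)O[C@H]1C[C@@H](C)C=C2C=C[C@H](C)[C@H](CC[C@@H]3C[C@@H](O)CC(=O)O3)C21` has not been measured. It differs from compound 2 by 1-methylethenyl in place of isopropyl on a saturated chain carbon bound to a carbonyl carbon. Going by the values given here, this alters the same ester side chain that the measured step altered, but no measured pair exchanges a saturated chain carbon for one carrying a double bond, so the step from compound 1 to compound 2 bears on it only loosely: it shows that this side chain can move the number by a modest amount. Given how small the present change is, the step of a 1.1-fold higher number from compound 2 to compound 3 (0.05 log units; within the scatter) is expected to be small, within the scatter, with no clear direction. Compound 3 is therefore estimated at 6 nM in this assay, with a range from 2.5 nM to 15 nM.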

Compound 3, half-maximal inhibitory concentration: 2.9 nM
Compound 3: middle estimate off by 2.1-fold (0.32 log units), on the high side, and the stated range covers the measured number.
By their numbers in this assay, from the lowest: compounds 3 and 2 (each within the scatter of the next); then compound 1.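

Ester side-chain notes after the third compound

In this assay the step of a 1.9-fold lower number from compound 2 to compound 3 (0.27 log units; within the scatter) stays within the scatter, so on a saturated chain carbon bound to a carbonyl carbon, 1-methylethenyl and isopropyl cannot be told apart on this read-out, and the double bond outside aromatic rings brings no measurable change here. The second new step, a 13-fold lower number from compound 1 to compound 3 (1.12 log units; beyond the scatter), which replaces the cyclopropyl group of the ester with an open-chain group, is large, so two different open-chain groups now stand apart from the cyclopropyl ester beyond the scatter, and no compound shown goes against this. The data shown offer no independent measurement that would explain either step.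

The three compounds do not settle whether the ring of cyclopropyl or the branching of the open-chain groups goes with the difference from compound 1. On these data alone, how this ester side chain responds to a longer chain such as n-hexyl, or to an amine or a carboxylic acid at its end, remains open.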